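A few compounds are considered here, and "the series" means these few. Any claim that something is new, unique, unknown or untested is made for them only; others in the source may bear on it.

Of the compounds shown here, three built on one shared core have been measured in an ADME assay on the whole organism for metabolic stability, with Rattus norvegicus as the target; on this read-out higher numbers stand for a longer-lived compound and lower numbers for a shorter-lived compound. Compound 1 `O=C(Nc1cccnc1-c1cccc(Cl)c1)N1CCN2C(=O)N([C@H]3C[C@@H]3c3ccccc3)C(=O)[C@@H]2C1` gives 1.3 h, and compound 3 `N#Cc1cccc(-c2ncccc2NC(=O)N2CCN3C(=O)N([C@H]4C[C@@H]4c4ccccc4)C(=O)[C@@H]3C2)c1` gives 3.8 h. Compound 2 `O=C(Nc1cccnc1-c1ccsc1)N1CCN2C(=O)N([C@H]3C[C@@H]3c3ccccc3)C(=O)[C@@H]2C1` gives 10 h, the highest of the three; both steps joining it to the others lie beyond the scatter, namely a 7.7-fold higher number from compound 1 to compound 2 (0.89 log units; beyond the scatter) and a 2.6-fold lower number from compound 2 to compound 3 (0.42 log units; beyond the scatter). Compound 4 `O=C(Nc1cccc(Cl)c1Cl)N1CCN2C(=O)N([C@H]3C[C@@H]3c3ccccc3)C(=O)[C@@H]2C1` alters a larger piece: 2,3-dichlorophenyl in place of 2-(thiophen-3-yl)pyridin-3-yl on an amide-type nitrogen. The measured steps, including a 2.9-fold higher number from compound 1 to compound 3 (0.47 log units; beyond the scatter), only exchange the group on the outer ring and leave the pyridine in place, so none bears directly on this change. Within the data shown here, the lowest number belongs to the one chloro-bearing compound, compound 1 with 1.3 h. A drop is therefore expected, a 4.0-fold lower number from compound 2 to compound 4 (0.60 log units; beyond the scatter), so compound 4 is estimated at 2.5 h, between 0.8 h and 8 h.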

Compound 4, half-life: 2.2 h
Compound 4: the middle estimate sits 1.1-fold (0.06 log units) above what was measured; low and high end bracket the measured number.
By their numbers in this assay, from the lowest: compounds 1, 4 and 3 (each within the scatter of the next, the first and the last beyond it); then compound 2.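

Putting 2,3-dichlorophenyl in place of 2-(thiophen-3-yl)pyridin-3-yl on the amide-type nitrogen gives a 4.5-fold lower number from compound 2 to compound 4 (0.66 log units; beyond the scatter) in this assay. Unlike the earlier steps, which kept the pyridine and exchanged only the outer group, this one replaces the whole group, showing that the half-life at this position also shifts when both rings go. Nothing measured here explains the drop.

Going by these compounds, compound 4 loses the pyridine and the thiophene and gains the chlorines all at once, so their separate shares stay unknown. On these data alone, how a plain phenyl or an aminophenyl would behave at this place also remains open.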